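Methyl to isopropyl on two related cores: cytotoxicity notes

The source may report more compounds than this note shows. Statements on the series, on what has been measured and on what is new or still open speak of the compounds shown alone.

Measured compounds:
compound 1, `C[C@H](NC(=O)c1ccccc1)c1n[nH]c(=S)o1` — 377000 nM
compound 2, `CC(C)[C@H](NC(=O)c1ccccc1)c1n[nH]c(=S)o1` — 245000 nM
compound 3, `C[C@H](NC(=O)c1ccccc1)c1n[nH]c(=S)n1N` — 372000 nM

All three numbers come from a functional assay on K562 cells (Homo sapiens) for cytotoxicity, read by MTT assay, with a stated time of 24 h; on this read-out lower numbers stand for stronger inhibition and higher numbers for weaker inhibition. Going by the values given here, the only change measured twice within one core is the one from compound 1 to compound 2, (isopropyl in place of methyl on a saturated chain carbon bound to an amide-type nitrogen and an aromatic carbon), and its step is a 1.5-fold lower number from compound 1 to compound 2 (0.19 log units; within the scatter). Compound 3 stands on a different core; the difference between the core of compound 1 and the core of compound 3 is not broken down here, and the two values lie within the scatter of each other, so nothing is read into their order.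

Compound 4, `CC(C)[C@H](NC(=O)c1ccccc1)c1n[nH]c(=S)n1N`, is not yet measured in this assay. Relative to compound 3 it carries isopropyl in place of methyl on a saturated chain carbon bound to an amide-type nitrogen and an aromatic carbon. Among the compounds with values here, the place given is word for word the one given for compound 1 to compound 2, so this is taken as the same change. The step expected from compound 3 to compound 4 is a 1.5-fold lower number from compound 3 to compound 4 (0.17 log units; within the scatter), set beside the earlier one because that step, a 1.5-fold lower number from compound 1 to compound 2 (0.19 log units; within the scatter), was small. For compound 4 the expected value in this assay is therefore 250000 nM, with a likely range from 130000 nM to 480000 nM.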

Compound 4, half-maximal inhibitory concentration: 154000 nM
The estimate for compound 4 lay 1.6-fold (0.21 log units) above the measured number; the range from low to high includes it.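

In this assay, isopropyl in place of methyl gives a 2.4-fold lower number from compound 3 to compound 4 (0.38 log units; beyond the scatter), a modest step on this core that lies beyond the scatter. Set beside the same change on the core of compound 1, the size of the step cannot be told apart between the two cores, so the change carries over as far as these compounds can show: the same change on two cores in this assay, a 1.5-fold lower number (0.19 log units; within the scatter) from compound 1 to compound 2 and a 2.4-fold lower number (0.38 log units; beyond the scatter) from compound 3 to compound 4, 1.6-fold (0.20 log units) apart, within the scatter of two such steps This does not show that the core of compound 3 responds more strongly than the core of compound 1, and a single pair on each core, one of them with a step within the scatter, sets no rule for the series.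

As far as these compounds go, what a longer chain or a phenyl group would do in place of isopropyl on the saturated chain carbon remains open. Also open, from the compounds shown here alone, is whether an amine or a carboxylic acid at that place would behave alike on the two cores.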